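The compounds below may be only part of what the source reports. "The series", "measured", "known", "first", "only" and "open" are said of these compounds alone.

Measured in a functional assay on CCRF-CEM cells (Homo sapiens) for antiproliferative activity, read by sulforhodamine B assay, with a stated time of 48 h; a higher number here means a weaker inhibitor of growth, a lower number a stronger inhibitor of growth:
- Compound 1 `O=C(NCCCNc1cc(-c2cn(-c3ccccc3)nc2-c2cccc(O)c2)ccn1)Nc1ccc(F)cc1`: > 25000 nM (a limit)
- Compound 2 `O=C(NCCCNc1cc(-c2cn(-c3ccccc3)nc2-c2cccc(O)c2)ccn1)Nc1cccc(C(F)(F)F)c1`: > 33300 nM (a limit)

Neither compound has a true number, only a limit. Compound 1 therefore stands at the limit of > 25000 nM in this assay, at which 1 of the 2 values shown sits, and compound 2 offers no firmer reference point.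

Compound 3 `COc1cccc(-c2nn(-c3ccccc3)cc2-c2ccnc(NCCCNC(=O)Nc3ccc(F)cc3)c2)c1` is the unmeasured partner of compound 1. It is built by methyl in place of hydrogen on an oxygen on an aromatic ring, which turns 3-hydroxyphenyl into 3-methoxyphenyl. Going by the values given here, the only measured step, a step that the two limits leave unreadable from compound 1 to compound 2, has no readable size and lies at a different place in the molecule, so it offers little guidance. With nothing to suggest a real shift, no step beyond the usual scatter is expected in this assay, and a further limit is the likeliest result. The expected step is a step that the limit leaves unreadable from compound 1 to compound 3. For compound 3 the estimated value is 30000 nM, with an expected range of 10000 nM to 100000 nM.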

Compound 3, concentration for total growth inhibition: 31500 nM
Compound 3: the middle estimate sits 1.1-fold (0.02 log units) below what was measured, and the stated range covers the measured number.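

Compound 1 has only a limit in this assay, so no step can be read from compound 1 to compound 3, which carries 3-methoxyphenyl in place of 3-hydroxyphenyl. The compounds shown leave open whether this change affects growth inhibition at all, and by how much.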